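Amide substituent change in a paw edema series

The source may report more compounds than this note shows. Statements on the series, on what has been measured and on what is new or still open speak of the compounds shown alone.

Compound 1 `O=C(NC1CCN(Cc2ccccc2)CC1)c1c(O)c2cccnc2n(-c2ccccc2)c1=O`: 1.7%
Compound 2 `Cc1cccc(NC(=O)c2c(O)c3cccnc3n(-c3ccccc3)c2=O)c1`: 14.2%

In a functional assay on the whole organism for inhibition, with Rattus norvegicus as the target, read by paw edema, at a dose of 100 mg/kg by the oral route (on this read-out lower numbers stand for less inhibition and higher numbers for more inhibition at the one dose given (going by the name of the read-out)), compound 2 gives 14.2%, the higher of the two numbers measured. Compound 1 gives 1.7%, lower by a margin beyond the scatter. Compound 3 `Cc1cnccc1NC(=O)c1c(O)c2cccnc2n(-c2ccccc2)c1=O` differs from compound 2 by 3-methylpyridin-4-yl in place of 3-methylphenyl on an amide-type nitrogen. Within the data shown here, no step between measured compounds carries a comparable change, so the direction cannot be read from the data; a step near or within the scatter is the most reasonable expectation. Compound 3 is expected to give 12%, with a range of 3% to 25%. The expected step of a number 2.2 percentage points lower from compound 2 to compound 3 (within the scatter) is small, not clearly beyond the scatter.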

Compound 3, a percentage reported as inhibition, in the whole organism at one dose (the size of the read-out at that dose, not a potency): 26.9%
Estimate against measurement, compound 3: 14.9 percentage points below; measured number above the stated range.
By their numbers in this assay, from the lowest: compound 1; then compound 2; then compound 3.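

In this assay, 3-methylpyridin-4-yl in place of 3-methylphenyl on the amide-type nitrogen gives a number 12.7 percentage points higher from compound 2 to compound 3 (beyond the scatter) and is the only step shown at this position. The position therefore responds to this exchange, in which one ring carbon gives way to nitrogen and one hydrogen-bond acceptor enters with no net charge. No measured evidence available here accounts for the rise.

On these data alone, whether the methyl group on the pyridine ring contributes remains open, as does the outcome with unsubstituted pyridin-4-yl or a carboxylic acid on that ring. Readings at one dose also leave the dose response of the series unresolved.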